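Swapping fluoro for nitro on a thiophene-bearing benzoyl series

A few compounds are considered here, and "the series" means these few. Any claim that something is new, unique, unknown or untested is made for them only; others in the source may bear on it.

In a functional assay on BHK-21 cells (Mesocricetus auratus) for cytotoxicity, read by MTT assay (a lower number here means that less compound is tolerated, a higher number that more compound is tolerated), compound 1 (`O=C(c1ccccc1)N1N=C(c2cccs2)CC1c1ccc(Cl)cc1`) reads > 300000 nM, which is a limit rather than a number (the limit of > 300000 nM in this assay, at which 1 of the 2 values shown sits). For the measured compounds named here, compound 2 (`O=C(c1ccccc1)N1N=C(c2cccs2)CC1c1ccc(F)cc1`) gives 100000 nM, the only actual number so far. Going by the values given here, the one measured step, an at least 3.0-fold lower number from compound 1 to compound 2 (0.47 log units; beyond the scatter), is also a change on an aromatic carbon. Compound 3 (`O=C(c1ccccc1)N1N=C(c2cccs2)CC1c1ccc([N+](=O)[O-])cc1`) places nitro in place of fluoro on an aromatic carbon. Among the compounds with values here, with only that step as a guide, a shift of similar modest size or none is expected in this assay, with no firm direction, leaning slightly lower. The expected step is a 1.3-fold lower number from compound 2 to compound 3 (0.10 log units; within the scatter). Compound 3 is estimated at 80000 nM, within a range of 25000 nM to 300000 nM.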

Compound 3, half-maximal cytotoxic concentration: > 300000 nM
Compound 3 ended at the assay's limit; the forecaster's own chance of this, stated with the estimate: 25%; middle value at least 3.7-fold (0.57 log units) away from the limit.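

With fluoro as the starting point, this assay now shows an at least 3.0-fold higher number from compound 2 to compound 3 (0.47 log units; beyond the scatter), so the fluoro compound reads lower than both the chloro and nitro compounds at this position. Compound 3 gives > 300000 nM, which is a limit and not a number. The step between compound 1 and compound 3 cannot be read, and the two share one ceiling: the limit of > 300000 nM in this assay, at which 2 of the 3 values shown sit. As far as these compounds go, how far compound 1 and compound 3 lie past that limit remains open, as does whether an amine or a carboxylic acid at this place would give a measurable number.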